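The compounds below may be only part of what the source reports. "The series", "measured", "known", "first", "only" and "open" are said of these compounds alone.

Measured compounds, with the half-maximal inhibitory concentration in a functional assay (aorta) with Rattus norvegicus as the target; on this read-out higher numbers stand for weaker inhibition and lower numbers for stronger inhibition:
compound 1 `CC1(C)Oc2ccc(C#N)cc2[C@@H](/N=C(\NC#N)Nc2ccc(Cl)cc2)[C@@H]1O` gives 1800 nM
compound 2 `COC(=O)c1cc2ccccc2n1[C@@H]1c2cc(C#N)ccc2OC(C)(C)[C@H]1O` gives 33000 nM
compound 3 `CCOC(=O)CCN(c1ccccc1)[C@H]1c2cc(C#N)ccc2OC(C)(C)[C@@H]1O` gives 54000 nM

Compound 3 has the highest number of the three. Its nearest neighbour is compound 2, and the gap between them is within the scatter; the gap to compound 1 is beyond the scatter. Going by the values given here, no step between two measured compounds that differ in one place is available, so nothing can be said about the effect of any single change on the measured set.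

Compound 4 `CC1(C)Oc2ccc(C#N)cc2[C@H](N(Cc2ncco2)c2ccccc2)[C@H]1O` differs from compound 3 in one place: 1,3-oxazol-2-yl in place of (ethoxycarbonyl)methyl on a saturated chain carbon bound to a nitrogen on an aromatic ring

Without a comparable measured step, the expectation rests on the change alone: a modest step toward a lower number is expected from compound 3 to compound 4, a 2.7-fold lower number from compound 3 to compound 4 (0.43 log units; beyond the scatter), possibly not beyond the scatter. Compound 4 is estimated at 20000 nM in this assay, within 5000 nM to 60000 nM.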

Compound 4, half-maximal inhibitory concentration: > 30000 nM
Compound 4: a limit, no number; the forecaster's own chance of this, stated with the estimate: 10%; middle value at least 1.5-fold (0.17 log units) away from the limit.
By their numbers in this assay, from the lowest: compound 1; then compounds 2 and 3 (each within the scatter of the next).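

In this assay, going by these compounds alone, compound 4 gives > 30000 nM, a limit and not a number, so no step from compound 3 to compound 4 can be read. The compounds shown leave open how 1,3-oxazol-2-yl in place of (ethoxycarbonyl)methyl changes the number.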